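The compounds below may be only part of what the source reports. "The series", "measured", "known", "first", "only" and "open" are said of these compounds alone.

Of the compounds shown here, two have so far been measured in an assay on liver for inhibition of sterol O-acyltransferase 1 (Rattus norvegicus), using microsomes; a lower number here means a stronger inhibitor, a higher number a weaker inhibitor. Compound 1 `CC(C)c1cccc(C(C)C)c1OC(=O)NS(=O)(=O)NC(c1ccccc1)c1ccccc1` gives 10600 nM, while compound 2 `Cc1cc(C(C)(C)C)c(OC(=O)NS(=O)(=O)N(C(C)C)C(C)C)c(C(C)(C)C)c1` gives 3200 nM, the lower of the two numbers and so the stronger inhibitor, with a gap to compound 1 that lies beyond the usual scatter. Compound 3 `Cc1cc(C(C)(C)C)c(OC(=O)NS(=O)(=O)Oc2ccccc2)c(C(C)(C)C)c1` differs from compound 2 in a single place: phenoxy in place of diisopropylamino on a sulfonyl sulfur. Among the compounds with values here, no measured pair shows a change of this kind, so its effect is uncertain. The expected step of a 1.6-fold higher number from compound 2 to compound 3 (0.19 log units; within the scatter) is a slight weakening, near the edge of the scatter. Compound 3 is therefore estimated at 5000 nM in this assay, within a range from 1500 nM to 16000 nM.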

Compound 3, half-maximal inhibitory concentration: 90000 nM
Compound 3: the middle estimate sits 18-fold (1.26 log units) below what was measured, and the stated range ends below it.
By their numbers in this assay, from the lowest: compound 2; then compound 1; then compound 3.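

With phenoxy in place of diisopropylamino on a sulfonyl sulfur, there is a 28-fold higher number from compound 2 to compound 3 (1.45 log units; beyond the scatter) in this assay even though both groups hold the same count of heavy atoms. This position is therefore far from indifferent to what it carries, and a heavy-atom count alone does not predict the outcome. No measurement shown explains this loss.

From the compounds shown here alone, it remains open whether the linking oxygen or the aromatic ring matters more. An anilino group or a cyclohexyloxy group on the same sulfur would help separate the two.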